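The source may hold more compounds than are shown below. What is called first, only, known or untested is meant among the compounds shown, and "the series" means these compounds.

Measured in a functional assay on HeLa cells (Homo sapiens) for inhibition, with a stated time of 72 h; on this read-out higher numbers stand for an effect only at larger amounts of compound and lower numbers for an effect already at smaller amounts:
- compound 1 `COc1cc(CNCc2ccncc2)ccc1OCc1ccc(Cl)c(Cl)c1`: 4000 nM
- compound 2 `COc1cc(CNCc2ccncc2)ccc1OCc1ccc(Cl)nc1`: 400 nM

Compound 2, at 400 nM, holds the lower of the two numbers in this assay, so an effect appears at smaller amounts of it than of compound 1.

Next comes compound 3 `COc1cc(CNCc2ccncc2)ccc1OCc1ccc(Cl)cc1Cl`, with 2,4-dichlorophenyl in place of 6-chloropyridin-3-yl on a saturated chain carbon bound to an oxygen on an aromatic ring.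

Among the compounds with values here, one measured step bears on this change: a 10-fold lower number from compound 1 to compound 2 (1.00 log units; beyond the scatter). It swapped 3,4-dichlorophenyl for 6-chloropyridin-3-yl at the same place, so compound 3 goes back to a dichlorophenyl group, though not the same one. Within the data shown here, no measured compound carries 2,4-dichlorophenyl, and nothing shows how it compares with 3,4-dichlorophenyl. A step towards a higher number is therefore expected, beyond the scatter but perhaps not as large as the measured one, since only compound 1 at 4000 nM serves as a guide.

The estimate is a 5.0-fold higher number from compound 2 to compound 3 (0.70 log units; beyond the scatter). For compound 3 the expected value is 2000 nM, with an estimated range of 600 nM to 6000 nM.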

Compound 3, half-maximal effective concentration: 3900 nM
For compound 3 the middle estimate is 2.0-fold (0.29 log units) below the measured one; the range from low to high includes it.
By their numbers in this assay, from the lowest: compound 2; then compounds 3 and 1 (each within the scatter of the next).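

Placing 2,4-dichlorophenyl where compound 2 carries 6-chloropyridin-3-yl, on a saturated chain carbon bound to an oxygen on an aromatic ring, gives a 9.8-fold higher number from compound 2 to compound 3 (0.99 log units; beyond the scatter) in this assay, so the advantage of compound 2 now holds against two different dichlorophenyl groups rather than only the one in compound 1. The comparison of the two dichlorophenyl groups gives a 1.0-fold lower number from compound 1 to compound 3 (0.01 log units; within the scatter), so this pair shows no readable difference on this read-out between 2,4-dichlorophenyl and 3,4-dichlorophenyl at this place. No measurement on hand gives a reason why 6-chloropyridin-3-yl stands apart from both dichlorophenyl groups.

Compound 2 differs from compounds 1 and 3 both in having a nitrogen in the ring and in carrying one chlorine instead of two, and the compounds shown do not separate these two differences. A 4-chlorophenyl group at this place would test the chlorine count with a ring of carbon only, while a pyridin-3-yl group without chlorine would show whether the remaining chlorine of compound 2 matters.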